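The compounds below may be only part of what the source reports. "The series", "measured", "known", "first", "only" and "open" are said of these compounds alone.

In a functional assay on U-373MG ATCC cells (Homo sapiens), read by thymidine incorporation (on this read-out higher numbers stand for weaker inhibition and lower numbers for stronger inhibition), the three measured compounds stand as follows.

Compound 1, `CC(=O)N[C@H]1[C@@H](OCCCCc2ccccc2)O[C@H](CO)[C@@H](O)[C@@H]1O`, gives > 50 uM, which is a limit of the assay and not a number.
Compound 2, `CCCCCCCCCCCCCCCCO[C@H]1O[C@H](CO)[C@@H](O)[C@H](O)[C@H]1NC(C)=O`, gives > 50 uM, again a limit of the assay.
Compound 3, `C=CCCC(=O)N[C@H]1[C@@H](OCCc2ccccc2)O[C@H](CO)[C@@H](O)[C@@H]1O`, gives > 50 uM, likewise a limit of the assay.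

Compound 3 therefore does not stand at a measured point at all: its result is a limit, and it shares that position with the other two compounds, as all three sit at the limit of > 50 uM in this assay, at which 3 of the 3 values shown sit. For the measured compounds named here, none of the measured compounds differs from another in only one place, so no measured step in this assay exists to lean on.

Compound 4, `C=CCCC(=O)N[C@H]1[C@@H](OCCc2ccccc2)O[C@H](CO)[C@@H](O)[C@@H]1OS(=O)(=O)O`, is the unmeasured partner of compound 3. The change is sulfo in place of hydrogen on an oxygen on a saturated carbon. Read one bond further out, a hydroxy becomes a sulfooxy.

With every measured compound at the limit, nothing here shows a change of this kind moving the read-out in either direction. The expected step from compound 3 to compound 4 is therefore a step that the limit leaves unreadable from compound 3 to compound 4, that is, nothing beyond the scatter, and a limit is again the most likely outcome. For compound 4 the estimate is 80 uM, within a range from 25 uM to 300 uM.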

Compound 4, concentration for 50% inhibition: > 50 uM
Compound 4 gave a limit, no number; the forecaster's own chance of this, stated with the estimate: 80%; the middle value does not contradict the limit.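

In this assay no step can be read from compound 3 to compound 4, as both results are limits of the assay and not numbers, and the same holds for every compound shown: the limit of > 50 uM in this assay, at which 4 of the 4 values shown sit.

The compounds shown leave open whether hydroxy to sulfooxy changes inhibition at all, and how large any such change would be.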